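The source may hold more compounds than are shown below. What is called first, only, known or untested is meant among the compounds shown, and "the series" means these compounds.

Three compounds share one core and differ only in the group carried on a sulfonyl sulfur. Compound 1 `COCCN(C)S(=O)(=O)c1ccc(C)c(C#Cc2cc(Cl)ccc2OCC(=O)O)c1` gives 4.1 nM in an assay on CHO cells for displacement of a labelled ligand from prostaglandin D2 receptor 2 (Homo sapiens), read by scintillation counting; a lower number here means a stronger inhibitor, a higher number a weaker inhibitor. Compound 2 `CCS(=O)(=O)c1ccc(C)c(C#Cc2cc(Cl)ccc2OCC(=O)O)c1` gives 8.6 nM in this assay, a step of a 2.1-fold higher number from compound 1 to compound 2 (0.32 log units; beyond the scatter). Compound 3 `Cc1ccc(S(=O)(=O)N2CCCCC2C)cc1C#Cc1cc(Cl)ccc1OCC(=O)O` gives 1.9 nM in this assay, the lowest of the three numbers, reached through a 2.2-fold lower number from compound 1 to compound 3 (0.33 log units; beyond the scatter) and through a 4.5-fold lower number from compound 2 to compound 3 (0.66 log units; beyond the scatter).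

Compound 4 `Cc1ccc(S(=O)(=O)N2CCOCC2)cc1C#Cc1cc(Cl)ccc1OCC(=O)O` has not yet been measured. It differs from compound 3 by morpholin-4-yl in place of 2-methylpiperidin-1-yl on a sulfonyl sulfur. For the measured compounds named here, of the measured steps, the one from compound 1 to compound 3 bears most on this change, since both compound 1 and compound 4 carry an amine with an oxygen on the sulfonyl sulfur, while compound 3 carries an amine without one. That step was modest and beyond the scatter. The two cyclic amines resemble each other more closely than either resembles the open chain of compound 1, so a step back toward compound 1 of modest size is expected, a 2.4-fold higher number from compound 3 to compound 4 (0.37 log units; beyond the scatter). Compound 4 is therefore estimated at 4.5 nM, with a range from 1.8 nM to 11 nM.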

Compound 4, inhibition constant: 3.6 nM
For compound 4 the middle estimate is 1.3-fold (0.10 log units) above the measured one; the measured number falls inside the stated range.
By their numbers in this assay, from the lowest: compounds 3, 4 and 1 (each within the scatter of the next, the first and the last beyond it); then compound 2.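

On the sulfonyl sulfur, morpholin-4-yl and 2-methylpiperidin-1-yl cannot be told apart in this assay (a 1.9-fold higher number from compound 3 to compound 4 (0.28 log units; within the scatter)), so this position accepts a ring with a second hetero atom and no methyl group without a change beyond the scatter. The same holds against the open chain of compound 1 (a 1.1-fold lower number from compound 1 to compound 4 (0.06 log units; within the scatter)), whereas the ethyl group of compound 2 stays apart from the morpholine ring (a 2.4-fold lower number from compound 2 to compound 4 (0.38 log units; beyond the scatter)), which makes all three nitrogen-linked groups here give lower numbers than ethyl. Nothing available explains these results.

As far as these compounds go, whether the ring oxygen and the methyl group each matter on their own remains open, and a plain piperidin-1-yl group on the same sulfur would separate the two. A piperazin-1-yl ring, with a second ring nitrogen where morpholine has its oxygen, would show whether this tolerance extends to a ring amine.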